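Fluorophenyl amide in a series stuck at the limit

A few compounds are considered here, and "the series" means these few. Any claim that something is new, unique, unknown or untested is made for them only; others in the source may bear on it.

Compound 1 `Cc1ccc(NC(=O)c2cccc(/C=C3\CC(=O)N(c4ccccc4)C3=O)c2)cc1C`: in an ADME assay on HCT-116 cells (Homo sapiens) for cytotoxicity, read by MTT assay, with a stated time of 72 h (a higher number here means a weaker inhibitor, a lower number a stronger inhibitor), compound 1 gives > 100000 nM, a limit of the assay rather than a number.
Compound 2 `COc1ccc(NC(=O)c2cccc(/C=C3\CC(=O)N(c4ccccc4)C3=O)c2)cc1`: in this assay compound 2 gives > 100000 nM, again only a limit.
Compound 3 `O=C(NCc1ccccc1)c1cccc(/C=C2\CC(=O)N(c3ccccc3)C2=O)c1`: in this assay compound 3 gives > 100000 nM, also a limit.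

Compound 3 therefore stands where the other two stand, at the limit of > 100000 nM in this assay, at which 3 of the 3 values shown sit; for compound 3 only this limit is known. The steps a step that the two limits leave unreadable from compound 1 to compound 2, a step that the two limits leave unreadable from compound 1 to compound 3 and a step that the two limits leave unreadable from compound 2 to compound 3 are all unreadable for the same reason, and none of them can size a further change at this position. Compound 4 `O=C(Nc1cccc(F)c1)c1cccc(/C=C2\CC(=O)N(c3ccccc3)C2=O)c1` arises from compound 3 by 3-fluorophenyl in place of benzyl on an amide-type nitrogen. With every measured value at the limit, a step that the limit leaves unreadable from compound 3 to compound 4 is expected, that is, no readable movement. Compound 4 is accordingly estimated at 150000 nM, with a range from 40000 nM to 600000 nM, most likely reported again as a limit only.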

Compound 4, half-maximal inhibitory concentration: > 100000 nM
Compound 4: only a limit was reported; the forecaster's own chance of this, stated with the estimate: 80%; the middle value is on the limit's open side.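

For the compounds shown here, compound 4 gives only a limit, as do compound 1, compound 2 and compound 3, so no step to compound 4 can be read. The compounds shown leave open whether any amide substituent on the shared core gives a measurable value in this assay at all.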